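The compounds below may be only part of what the source reports. "The series", "measured", "known", "first", "only" and "open" are said of these compounds alone.

Two sugar-derived compounds that carry two aryl ether arms have been tested in a functional assay on MDA-MB-231 cells (Homo sapiens) for cytotoxicity, read by MTT assay, with a stated time of 48 h; on this read-out lower numbers stand for an effect already at smaller amounts and higher numbers for an effect only at larger amounts of compound. Compound 1 `CO[C@@H]1O[C@H](COc2ccc(-c3ccccc3)cc2)[C@@H](O)[C@H](O)[C@H]1Oc1ccc(OC2CCCCC2)cc1` bears a biphenyl on one arm and a cyclohexyloxy-bearing phenyl on the other; in this assay compound 1 gives 36000 nM. Compound 2 `CO[C@@H]1O[C@H](COc2ccc(OC3CCCCC3)cc2)[C@@H](O)[C@H](O)[C@H]1Oc1ccc(C(C)C)cc1` keeps a cyclohexyloxy-bearing phenyl on one arm and carries an isopropyl-bearing phenyl on the other; in this assay compound 2 gives 35000 nM. Compound 2 thus shows the lower of the two numbers, yet its gap to compound 1 lies within the usual scatter of such measurements, so the two compounds cannot be told apart.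

Compound 3 `CO[C@@H]1O[C@H](COc2ccc(OC3CCCCC3)cc2)[C@@H](O)[C@H](O)[C@H]1Oc1ccc(OC2CCCCC2)cc1` has not yet been measured. It differs from compound 2 in one place: cyclohexyloxy in place of isopropyl on an aromatic carbon. Both arms of compound 3 therefore end in the same cyclohexyloxy-bearing phenyl. Compound 1 and compound 2 differ in the makeup of their arms and still give matching numbers, so this change is expected to move the read-out little. The expected step is a 1.2-fold lower number from compound 2 to compound 3 (0.07 log units; within the scatter), which amounts to nothing beyond the scatter. Compound 3 is accordingly estimated at 30000 nM, with a likely range from 12000 nM to 75000 nM.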

Compound 3, half-maximal effective concentration: 26000 nM
For compound 3 the middle estimate is 1.2-fold (0.06 log units) above the measured one, within the range that was stated.
By their numbers in this assay, from the lowest: compounds 3, 2 and 1 (each within the scatter of the next).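

In this assay, cyclohexyloxy in place of isopropyl gives a 1.3-fold lower number from compound 2 to compound 3 (0.13 log units; within the scatter), and cyclohexyloxy in place of phenyl on the other arm gives a 1.4-fold lower number from compound 1 to compound 3 (0.14 log units; within the scatter). Both steps lie within the scatter, so these one-place comparisons show that the read-out does not separate these groups on either arm, even though cyclohexyloxy brings a non-aromatic ring, an oxygen and more heavy atoms than isopropyl. No measurement at hand says why the read-out fails to separate them.

From the compounds shown here alone, the groups compared here, isopropyl, phenyl and cyclohexyloxy, all sit on the aromatic ring as uncharged carbon-rich groups, so it remains open whether an amine or a carboxylic acid on the same aromatic carbon would move the number beyond the scatter. Also open, going by these compounds, is whether a much smaller group, such as a methoxy or a lone fluorine, would leave the read-out equally unmoved, or whether changes elsewhere on the shared core matter more than changes on these arms.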